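Swapping Methyl for Nitro: Expected Dose for Compound 4

The source may hold more compounds than are shown below. What is called first, only, known or untested is meant among the compounds shown, and "the series" means these compounds.

Compound 1 `Cc1cccn2c(/C=N/OCc3cn(Cc4ccc([N+](=O)[O-])cc4)nn3)c(-c3ccc(F)cc3)nc12`: in a functional assay on the whole organism (strain NMRI) with Mus musculus as the target, with a stated time of 4 h (on this read-out higher numbers stand for an effect only at larger amounts of compound and lower numbers for an effect already at smaller amounts), compound 1 gives 40 mg/kg.
Compound 2 `Cc1ccc(Cn2cc(CO/N=C/c3c(-c4ccc(F)cc4)nc4ccc(Br)cn34)nn2)cc1`: compound 2 gives 100 mg/kg.
Compound 3 `Cc1ccc(Cn2cc(CO/N=C/c3c(-c4ccc(F)cc4)nc4c(C)cccn34)nn2)cc1`: compound 3 gives 40 mg/kg.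

Compound 1 and compound 3 share a core and differ only by nitro in place of methyl on an aromatic carbon. That change gave no change at the digits printed from compound 3 to compound 1 (within the scatter). Compound 2 carries another core; the difference between the two cores is not broken down here. Compound 2 stands highest of the three, beyond the scatter above both compound 1 and compound 3. Compound 4 `O=[N+]([O-])c1ccc(Cn2cc(CO/N=C/c3c(-c4ccc(F)cc4)nc4ccc(Br)cn34)nn2)cc1` is not yet measured. It differs from compound 2 by nitro in place of methyl on an aromatic carbon, the same change as from compound 3 to compound 1, at the same place. Because the earlier step of no change at the digits printed from compound 3 to compound 1 (within the scatter) stayed within the scatter, the step from compound 2 to compound 4 is expected to be no change at the digits printed from compound 2 to compound 4 (within the scatter). Compound 4 is therefore estimated at 100 mg/kg, plausibly between 50 mg/kg and 200 mg/kg.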

Compound 4, minimum effective dose: 100 mg/kg
Beside the measured number, compound 4's estimate shows no gap at the digits printed, and the stated range covers the measured number.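

In this assay, nitro in place of methyl on an aromatic carbon, turning 4-methylbenzyl into 4-nitrobenzyl, gave no change at the digits printed from compound 2 to compound 4 (within the scatter) and so matched the earlier step on the other core: the same change on two cores in this assay, no change at the digits printed (within the scatter) from compound 3 to compound 1 and no change at the digits printed (within the scatter) from compound 2 to compound 4, 1.0-fold (0.00 log units) apart, within the scatter of two such steps.

On these two cores, then, the change carried over, and this swap left the minimum effective dose where it stood. This is only two cases, however, and it does not show that the same would hold on a third core, nor does it explain why the dose stayed the same.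

The compounds shown carry only methyl or nitro at this place, so the effect of an amine, a carboxylic acid or a longer chain there remains open.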